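This account rests on a few compounds, and the source may have more. Where it says the series, first, only, none or still open, it means among the compounds named here.

Series notes. Three analogues on one shared core have been run in an assay on microsomes from intestine for inhibition of acyl-CoA:cholesterol acyltransferase (Oryctolagus cuniculus); a lower number here means a stronger inhibitor, a higher number a weaker inhibitor. Compound 1 `CC(C)c1cccc(C(C)C)c1OC(=O)NC(=O)Oc1cccc2ccccc12` gives 3700 nM; compound 2 `CC(C)c1cccc(C(C)C)c1OC(=O)NC(=O)OCc1ccccc1` gives 77 nM; compound 3 `CC(C)c1cccc(C(C)C)c1OC(=O)NC(=O)OCCCc1ccccc1` gives 660 nM. Compound 3 thus stands second highest of the three numbers, nearer to compound 1 than to compound 2. Among the measured compounds shown here, the only single-point step so far, an 8.6-fold higher number from compound 2 to compound 3 (0.93 log units; beyond the scatter), runs toward weaker inhibition as the chain grows. Compound 4 `CCCCCCOC(=O)NC(=O)Oc1c(C(C)C)cccc1C(C)C` differs from compound 3 as follows: propyl in place of phenyl on a saturated chain carbon, three bonds along the chain from an oxygen next to a carbonyl group. For the measured compounds named here, no measured pair removes an aromatic ring, so the step from compound 2 to compound 3 bears only indirectly, and the direction for compound 4 is open. Compound 4 is expected to give about 1200 nM, between 300 nM and 5000 nM. That estimate means an expected step of a 1.8-fold higher number from compound 3 to compound 4 (0.26 log units; within the scatter), modestly toward a higher number.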

Compound 4, half-maximal inhibitory concentration: 53 nM
Compound 4: the middle estimate sits 23-fold (1.35 log units) above what was measured; measured number below the stated range.
By their numbers in this assay, from the lowest: compounds 4 and 2 (each within the scatter of the next); then compound 3; then compound 1.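

At this position an aromatic ring is dispensable in this assay: the change from 3-phenylpropyl to hexyl gives a 12-fold lower number from compound 3 to compound 4 (1.10 log units; beyond the scatter). The ring-free hexyl chain of compound 4 also sits level with the benzyl group, at a 1.5-fold lower number from compound 2 to compound 4 (0.16 log units; within the scatter), so a long chain at this place is compatible with a number like that of compound 2. Nothing available explains the difference between the phenyl and propyl ends.

From the compounds shown here alone, whether a longer chain such as octyl would hold this number remains open. So does the effect of an amine or a carboxylic acid at the chain end.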